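Bromo for Chloro in a Small Oxime Series

The source may report more compounds than this note shows. Statements on the series, on what has been measured and on what is new or still open speak of the compounds shown alone.

Of the compounds shown here, three have been measured in a functional assay (Mus musculus, strain Balb/c) for inhibition, read by ELISA, with a stated time of 72 h; a higher number here means a weaker inhibitor, a lower number a stronger inhibitor. Compound 1 `O/N=C(\C=C\c1ccc(Cl)cc1)c1ccc(Cl)cc1` gives 9150 nM. Compound 3 `O/N=C(\C=C\c1ccc(Cl)cc1)c1ccc(Br)cc1` gives 14700 nM in this assay. Compound 2 `O/N=C(\C=C\c1cccs1)c1ccc(Cl)cc1` gives 9590 nM in this assay, a number that sits close to compound 1 and a little apart from compound 3, though none of the gaps among the three pass beyond the usual scatter. The difference between the core of compound 1 and the core of compound 2 is not broken down here.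

Compound 1 and compound 3 differ in one place only: bromo in place of chloro on an aromatic carbon. This change produced a 1.6-fold higher number from compound 1 to compound 3 (0.21 log units; within the scatter).

Compound 4 `O/N=C(\C=C\c1cccs1)c1ccc(Br)cc1` has not yet been measured. It stands to compound 2 as compound 3 stands to compound 1: bromo in place of chloro on an aromatic carbon. Both changes sit at the same kind of place, so this is the same change made on the core of compound 2 instead of the core of compound 1.

The expectation for compound 4 rests on that single precedent. Because the change from compound 1 to compound 3 gave a 1.6-fold higher number from compound 1 to compound 3 (0.21 log units; within the scatter), the step from compound 2 to compound 4 in this assay is expected to be of similar size, a 1.5-fold higher number from compound 2 to compound 4 (0.16 log units; within the scatter). Compound 4 is therefore estimated to give about 14000 nM in this assay, with a plausible range from 7000 nM to 28000 nM.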

Compound 4, half-maximal inhibitory concentration: 11200 nM
For compound 4 the middle estimate is 1.3-fold (0.10 log units) above the measured one; low and high end bracket the measured number.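

In this assay, bromo in place of chloro on an aromatic carbon gave a 1.2-fold higher number from compound 2 to compound 4 (0.07 log units; within the scatter), so on the core of compound 2, as on the core of compound 1, the step stays within the scatter. Set side by side, the two steps agree as far as these measurements can tell: the same change on two cores in this assay, a 1.6-fold higher number (0.21 log units; within the scatter) from compound 1 to compound 3 and a 1.2-fold higher number (0.07 log units; within the scatter) from compound 2 to compound 4, 1.4-fold (0.14 log units) apart, within the scatter of two such steps. This shows that the change carried over to a second core without a step beyond the scatter on either one, but it does not show that bromo and chloro truly differ in this assay, and two cores do not make a rule for any other core in the series.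

The compounds shown carry only chloro or bromo on the six-membered aromatic ring of carbon only, so they leave open how fluoro, methoxy, an amine or a carboxylic acid at that place would read in this assay. All of them also keep the oxime, and whether a carbonyl or a methyl ether of the oxime could stand in its place remains an open question, as does any reading of these compounds outside this one assay.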